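The source may hold more compounds than are shown below. What is called first, only, known or untested is meant among the compounds shown, and "the series" means these compounds.

Measured compounds:
- compound 1, `CC(C)(C)c1cccc(N2CCNCC2)n1`: > 300 mg/kg
- compound 2, `c1ccc(CCc2cccc(N3CCNCC3)n2)cc1`: > 300 mg/kg
- compound 3, `c1cc(CC2CCCCC2)nc(N2CCNCC2)c1`: 100 mg/kg

In a functional assay on the whole organism with Mus musculus as the target, in the maximal electroshock model, with a stated time of 120 min (a higher number here means that more compound is needed for the effect, a lower number that less compound is needed), compound 1 reaches only a limit, > 300 mg/kg, not a number. Compound 2 likewise reaches only a limit in this assay, > 300 mg/kg. Among the compounds with values here, compound 3 is the one member of the series with a number in this assay, 100 mg/kg; the other two values sit at the limit of > 300 mg/kg in this assay, at which 2 of the 3 values shown sit, so no step between measured compounds can be read, and compound 3 stands alone as the only figure from which to work.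

The next compound, compound 4, `CCCCCCCc1cccc(N2CCNCC2)n1`, has not yet been tested in this assay. It differs from compound 3 in one place: hexyl in place of cyclohexyl on a saturated chain carbon bound to an aromatic carbon. The change keeps the same count of heavy atoms and opens the ring into a chain of the same length.

Within the data shown here, with no measured step to lean on, the expected step from compound 3 to compound 4 in this assay is a 2.0-fold higher number from compound 3 to compound 4 (0.30 log units; within the scatter), a modest loss, close to the scatter, though a return to the limit would not surprise. Compound 4 is therefore estimated at 200 mg/kg in this assay, with a plausible range from 60 mg/kg to 300 mg/kg.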

Compound 4, minimum effective dose: 10 mg/kg
Beside the measured number, compound 4's estimate is 20-fold (1.30 log units) above it; the whole stated range lies above it.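

In this assay, within the data shown here, hexyl in place of cyclohexyl on a saturated chain carbon bound to an aromatic carbon gives a 10-fold lower number from compound 3 to compound 4 (1.00 log units; beyond the scatter), so with the same count of heavy atoms, the open chain and the ring are not interchangeable at this place, which the earlier compounds could not show. Pentyl in place of phenyl on a saturated chain carbon, two bonds along the chain from an aromatic carbon, gives an at least 30-fold lower number from compound 2 to compound 4 (1.47 log units; beyond the scatter), a step that starts from a limit of the assay for compound 2 and not from a number. The series now holds two numbers, and the other members stay at a limit of the assay: the limit of > 300 mg/kg in this assay, at which 2 of the 4 values shown sit.

Going by these compounds, it remains open whether a shorter chain such as butyl, a longer chain such as octyl, or a branched chain of the same size would hold the lower dose of compound 4 in this assay, and whether an ether oxygen or a terminal amine in the chain would be tolerated. What lies behind the step from the ring to the chain cannot be told from these values.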